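Adding a chloro group to the weaker of two hydrazone analogues

The source may report more compounds than this note shows. Statements on the series, on what has been measured and on what is new or still open speak of the compounds shown alone.

Among the measured compounds shown here, compound 2 `O=C(N/N=C/c1ccccc1O)c1cc(-c2ccccc2)nn1Cc1ccccc1` is the weaker of the two compounds measured so far. In a functional assay on A549 cells (Homo sapiens) for cytotoxicity, read by MTT assay, with a stated time of 96 h (on this read-out lower numbers stand for stronger inhibition and higher numbers for weaker inhibition), compound 2 gives 10800 nM, the higher of the two numbers. Compound 1 `O=C(N/N=C/c1ccccc1O)c1cc(-c2ccc(Cl)cc2)nn1Cc1ccc(Cl)nc1` differs from it in two places at once, and in this assay compound 1 gives 3680 nM, a difference that lies beyond the usual scatter. For the measured compounds named here, compound 3 `O=C(N/N=C/c1ccccc1O)c1cc(-c2ccc(Cl)cc2)nn1Cc1ccccc1` carries only one of those two changes: chloro in place of hydrogen on an aromatic carbon. Going by the values given here, no single measured pair isolates this change, so its effect can only be guessed from the two-place comparison between compound 2 and compound 1. Because compound 1 reached 3680 nM with this change plus a second one, compound 3 is expected to sit between the two measured values, with a modest improvement estimated as a 1.7-fold lower number from compound 2 to compound 3 (0.22 log units; within the scatter). Compound 3 is therefore expected to give about 6500 nM, within a range from 3000 nM to 14000 nM.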

Compound 3, half-maximal inhibitory concentration: 4870 nM
Estimate against measurement, compound 3: 1.3-fold (0.13 log units) above, and the stated range covers the measured number.
By their numbers in this assay, from the lowest: compounds 1 and 3 (each within the scatter of the next); then compound 2.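

Taken alone, the change from phenyl to 4-chlorophenyl gives a real gain in this assay, with a 2.2-fold lower number from compound 2 to compound 3 (0.35 log units; beyond the scatter), so this position on the ring responds to a single chloro group. The second change can now be read separately: replacing the 6-chloropyridin-3-yl group of compound 1 with phenyl gives a 1.3-fold higher number from compound 1 to compound 3 (0.12 log units; within the scatter), so that swap shows no effect that can be told apart from ordinary variation in this assay. No measurement shown here explains why the chloro group has this effect.

The compounds shown leave open how a fluoro, methoxy or amino group would compare with chloro at this place. They also leave open whether chloro elsewhere on the same ring would give a similar step.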